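The source may report more compounds than this note shows. Statements on the series, on what has been measured and on what is new or still open speak of the compounds shown alone.

Compound 1 `Cc1ccc(S(=O)(=O)N2C=CNC(=O)[C@H]2CC(=O)N[C@H]2CCN(C)CC2(C)C)cc1` and compound 2 `CCN1CC[C@H](NC(=O)C[C@@H]2C(=O)NC=CN2S(=O)(=O)c2ccc(C)cc2)C(C)(C)C1` share one core and differ only in the group on the ring amine nitrogen. In an in vitro functional assay on cells for antagonist activity at B1 bradykinin receptor (Homo sapiens), read by luminescence and calcium flux, with a stated time of 2 h (a lower number here means a stronger inhibitor, a higher number a weaker inhibitor), compound 1 gives 0.42 nM, and in this assay compound 2 gives 0.63 nM. Going by the values given here, the step of a 1.5-fold higher number from compound 1 to compound 2 (0.18 log units; within the scatter) is the only measured step, and it stays within the scatter, so compound 2 is not set apart from compound 1 on the numbers; it merely carries the higher of the two. Compound 3 `CCCN1CC[C@H](NC(=O)C[C@@H]2C(=O)NC=CN2S(=O)(=O)c2ccc(C)cc2)C(C)(C)C1` takes the change one bond further: methyl in place of hydrogen on a saturated chain carbon, two bonds along the chain from an amine nitrogen in a ring. The same kind of lengthening from compound 1 to compound 2 brought a 1.5-fold higher number from compound 1 to compound 2 (0.18 log units; within the scatter), so compound 3 is expected to stay close to compound 2 in this assay, with at most a small drift to a higher number, a 1.3-fold higher number from compound 2 to compound 3 (0.13 log units; within the scatter). The estimate for compound 3 in this assay is 0.85 nM, expected to fall between 0.3 nM and 2.5 nM.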

Compound 3, half-maximal inhibitory concentration: 0.51 nM
For compound 3 the middle estimate is 1.7-fold (0.22 log units) above the measured one, within the range that was stated.
By their numbers in this assay, from the lowest: compounds 1, 3 and 2 (each within the scatter of the next).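

Lengthening the group on the ring amine nitrogen from ethyl to propyl gives a 1.2-fold lower number from compound 2 to compound 3 (0.09 log units; within the scatter) in this assay and thus stays inside the scatter, as the step from methyl to ethyl did. Across the whole span from methyl to propyl the comparison gives a 1.2-fold higher number from compound 1 to compound 3 (0.08 log units; within the scatter) and also stays inside the scatter, so the numbers do not tell these three chains apart at this position. No measurement bearing on the reason for this result is given.

What the compounds shown leave open is whether a chain longer than propyl, a cyclopropyl ring, or a chain ending in a hydroxyl group or a carboxylic acid would stay as close. They also leave open how a bare hydrogen on the ring amine nitrogen would compare with these three chains.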